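This account rests on a few compounds, and the source may have more. Where it says the series, first, only, none or still open, it means among the compounds named here.

Measured so far:
compound 1 `CC(C)(Oc1ccc(Cl)cc1)C(=O)NCCOC(=S)Nc1ccc([N+](=O)[O-])cc1Cl`: > 800000 nM
compound 2 `CC(C)(Oc1ccc(Cl)cc1)C(=O)Oc1ccc(-c2cc(=S)ss2)cc1`: 675000 nM

In an ADME assay on H9c2 cells (Rattus norvegicus) for cytotoxicity, read by MTT assay, with a stated time of 48 h (on this read-out higher numbers stand for weaker inhibition and lower numbers for stronger inhibition), compound 1 gives only a limit, > 800000 nM, and no number. Compound 2 gives 675000 nM in this assay. Compound 3 `CC(C)(Oc1ccc(Cl)cc1)C(=O)NCCOC(=S)Nc1ccccc1` has not yet been measured; it differs from compound 1 by phenyl in place of 2-chloro-4-nitrophenyl on an amide-type nitrogen. Among the compounds with values here, no step between two measured compounds is known, so the size of such a change is untested here. Compound 1 sits at the limit of > 800000 nM in this assay, at which 1 of the 2 values shown sits, and with both numbers shown so high, the step of a number no higher from compound 1 to compound 3 (the limit leaves the size open) is expected to be small, none beyond the scatter in either direction. Compound 3 is therefore estimated at 800000 nM, between 300000 nM and 2000000 nM, quite possibly again reported only as a limit.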

Compound 3, half-maximal inhibitory concentration: > 800000 nM
Compound 3: no number, only a limit; the forecaster's own chance of this, stated with the estimate: 60%; the middle value lies on the limit itself.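

Within the data shown here, compound 1 and compound 3 each give only a limit, not a number, so no step between them can be read. As far as these compounds go, whether phenyl in place of 2-chloro-4-nitrophenyl on an amide-type nitrogen changes the value at all stays open.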